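Furan to thiophene on the enone chain

A few compounds are considered here, and "the series" means these few. Any claim that something is new, unique, unknown or untested is made for them only; others in the source may bear on it.

Among the compounds with values here, compound 3 `Cc1nc(NC(=O)c2ccccc2)sc1C(=O)/C=C/c1ccco1` gives 57.2% in an assay for inhibition of Polyunsaturated fatty acid 5-lipoxygenase (Homo sapiens), read by spectrophotometry, tested at 10 uM, in the presence of a further agent that is not named here (on this read-out lower numbers stand for less inhibition and higher numbers for more inhibition at the one concentration tested (going by the name of the read-out)), the lowest of the three numbers so far. Compound 1 `Cc1nc(NC(=O)c2ccccc2)sc1C(=O)/C=C/c1ccc(Cl)cc1` gives 63.7%, and the step of a number 6.5 percentage points lower from compound 1 to compound 3 (within the scatter) stays within the scatter. Compound 2 `Cc1nc(NC(=O)c2ccccc2)sc1C(=O)/C=C/c1cccc([N+](=O)[O-])c1` gives 98%, and the step of a number 40.8 percentage points lower from compound 2 to compound 3 (beyond the scatter) lies beyond it. Compound 4 `Cc1nc(NC(=O)c2ccccc2)sc1C(=O)/C=C/c1cccs1` carries thiophen-2-yl in place of furan-2-yl on a double-bonded chain carbon bound to a double-bonded chain carbon. Within the data shown here, no measured step exchanges thiophen-2-yl for furan-2-yl, so nothing bears directly on this change; the only steps touching this position are those from compound 1 and compound 2 named above, and an exchange between two five-membered aromatic rings with one hetero atom each is a closer change than either of them. For compound 4 the expected step is a number 2.8 percentage points higher from compound 3 to compound 4 (within the scatter), none beyond the scatter, giving an estimate of 60% with a range of 40% to 80%.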

Compound 4, a percentage reported as inhibition, at one concentration (the size of the read-out at that concentration, not a potency): 71.9%
The estimate for compound 4 lay 11.9 percentage points below the measured number, within the range that was stated.
By their numbers in this assay, from the lowest: compounds 3, 1 and 4 (each within the scatter of the next, the first and the last beyond it); then compound 2.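

The exchange of one five-membered aromatic ring for another, with the same heavy-atom count, is not silent at this position: a number 14.7 percentage points higher from compound 3 to compound 4 (beyond the scatter). Thiophen-2-yl still does not separate from 4-chlorophenyl, a number 8.2 percentage points higher from compound 1 to compound 4 (within the scatter), and falls well short of 3-nitrophenyl, a number 26.1 percentage points lower from compound 2 to compound 4 (beyond the scatter), so compound 2 remains clear of the other three. Nothing available accounts for the difference between the furan-2-yl and thiophen-2-yl compounds.

Open, as far as these compounds go, is how a 3-aminophenyl or pyridin-3-yl group would read at this place, and so whether the high number of compound 2 is tied to the nitro group.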